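Thiophene Swapped for Furan on a Trimethoxybenzoyl Pyrrole

A few compounds are considered here, and "the series" means these few. Any claim that something is new, unique, unknown or untested is made for them only; others in the source may bear on it.

In a functional assay on MCF7 cells (Homo sapiens) for inhibition, with a stated time of 96 h (a higher number here means a weaker inhibitor, a lower number a stronger inhibitor), compound 2 `COc1cc(C(=O)c2cn(-c3cccc(C)c3)cc2-c2ccsc2)cc(OC)c1OC` gives 65 nM, the higher of the two numbers available. Compound 1 `COc1cc(C(=O)c2cn(-c3cccc(N)c3)cc2-c2ccc(N)cc2)cc(OC)c1OC` gives 14 nM in this assay, so compound 2 stands as the weaker of the pair, beyond the scatter. Compound 3 `COc1cc(C(=O)c2cn(-c3cccc(C)c3)cc2-c2ccco2)cc(OC)c1OC` has not yet been measured in this assay; it differs from compound 2 by furan-2-yl in place of thiophen-3-yl on an aromatic carbon. Among the compounds with values here, no measured pair shows this exchange, so its size is unknown; the expectation is a small step, if any, and none beyond the scatter. Compound 3 is estimated at 100 nM, with a range from 30 nM to 350 nM. This expectation amounts to a step of a 1.5-fold higher number from compound 2 to compound 3 (0.19 log units; within the scatter).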

Compound 3, half-maximal inhibitory concentration: 23 nM
For compound 3 the middle estimate is 4.3-fold (0.64 log units) above the measured one; measured number outside the range, below it.
By their numbers in this assay, from the lowest: compounds 1 and 3 (each within the scatter of the next); then compound 2.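

In this assay, replacing thiophen-3-yl with furan-2-yl gives a 2.8-fold lower number from compound 2 to compound 3 (0.45 log units; beyond the scatter) even though the counts of heavy atoms, donors and acceptors stay the same. This position, two ring bonds from the ring atom that bears the 3-methylphenyl group, therefore responds to the identity of the five-membered aromatic ring placed there. No measurement shown accounts for this step.

The exchange alters the hetero atom and the attachment point together, and the compounds shown do not separate the two. Thiophen-2-yl, which pairs sulfur with the attachment point of furan-2-yl, remains an open comparison.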